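The source may hold more compounds than are shown below. What is called first, only, known or untested is meant among the compounds shown, and "the series" means these compounds.

Compound 1 `N#Cc1ccc(NC(=O)c2cc(Cc3ccccc3)ccc2O)cc1` gives 1930 nM in this study. Compound 2 `O=C(Nc1cc(C(F)(F)F)cc(C(F)(F)F)c1)c1ccc(-c2ccccc2)cc1O` gives 860 nM. Compound 3 `O=C(Nc1ccc(C(F)(F)F)cc1)c1ccc(F)cc1O` gives 740 nM.

In a functional assay on KG-1 cells (Homo sapiens) for cytotoxicity, read by luminescence and CellTiter-Glo, with a stated time of 3 days (a higher number here means a weaker inhibitor, a lower number a stronger inhibitor), compound 1 stands highest of the three numbers, and it is the weakest inhibitor of the set: its gap to compound 2 and its gap to compound 3 both lie beyond the usual scatter. No two of these compounds differ in a single place, so none of these gaps can be tied to one structural change.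

Compound 4 `Cc1ccc(O)c(C(=O)Nc2ccc(C#N)cc2)c1` differs from compound 1 at one site. hydrogen in place of phenyl on a saturated chain carbon bound to an aromatic carbon Cut one bond further out, the same difference reads benzyl to methyl.

Going by the values given here, no measured pair shows this change, so its size can only be an expectation. With compound 1 already the weakest of the three at 1930 nM, the removal of the phenyl is expected to give a modest step toward a weaker inhibitor, somewhat beyond the scatter, a 2.0-fold higher number from compound 1 to compound 4 (0.29 log units; within the scatter). Compound 4 is therefore estimated at 3800 nM, with a likely range from 1500 nM to 9000 nM.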

Compound 4, half-maximal inhibitory concentration: 3370 nM
Compound 4: middle estimate off by 1.1-fold (0.05 log units), on the high side; the measured number falls inside the stated range.
By their numbers in this assay, from the lowest: compounds 3 and 2 (each within the scatter of the next); then compounds 1 and 4 (each within the scatter of the next).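

Going by these compounds alone, compound 1 and compound 4 form the first pair here that differs in one place, so a single structural change can now be read in this assay. Hydrogen in place of phenyl on a saturated chain carbon bound to an aromatic carbon gives a 1.7-fold higher number from compound 1 to compound 4 (0.24 log units; within the scatter), so within this pair the phenyl, with its six carbon atoms, makes no difference that stands clear of the scatter. Nothing measured here offers an explanation for this result.

Going by these compounds, what an amine, a carboxylic acid or a longer chain on this carbon would give remains open. So does whether the same exchange would give a similar step on the core of compound 2 or compound 3, which carry trifluoromethyl groups instead of the nitrile.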